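The compounds below may be only part of what the source reports. "The series", "measured", "known", "first", "only" and "open" are said of these compounds alone.

Values so far in a functional assay on THP-1 cells (Homo sapiens) for cytotoxicity, read by MTT assay, with a stated time of 24 h; on this read-out higher numbers stand for weaker inhibition and lower numbers for stronger inhibition 
- compound 1 `CN1C/C(=C\c2ccc(Br)cc2)C(=O)/C(=C/c2cccc([N+](=O)[O-])c2)C1` (7690 nM)
- compound 2 `CN1C/C(=C\c2cccc([N+](=O)[O-])c2)C(=O)/C(=C/c2ccc(Cl)c(Cl)c2)C1` (5020 nM)

Compound 2 stands at 5020 nM and, on these two numbers, cannot be told apart from compound 1 (7690 nM). Compound 3 `CN1C/C(=C\c2cccc(Br)c2)C(=O)/C(=C/c2cccc([N+](=O)[O-])c2)C1` has not yet been measured. It carries 3-bromophenyl in place of 3,4-dichlorophenyl on a double-bonded chain carbon bound to a double-bonded ring carbon. For the measured compounds named here, the only measured step at that place is a 1.5-fold lower number from compound 1 to compound 2 (0.19 log units; within the scatter) and it is a single example, so it offers weak guidance. On that evidence, no step beyond the scatter is expected in this assay for this change. The estimated step is a 1.2-fold higher number from compound 2 to compound 3 (0.08 log units; within the scatter) and it is expected to stay within the scatter. For compound 3 the estimated value is 6000 nM (expected range 2800 nM to 13000 nM).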

Compound 3, half-maximal inhibitory concentration: 4030 nM
Estimate against measurement, compound 3: 1.5-fold (0.17 log units) above, and the stated range covers the measured number.
By their numbers in this assay, from the lowest: compounds 3, 2 and 1 (each within the scatter of the next).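

In this assay, the place on a double-bonded chain carbon bound to a double-bonded ring carbon now has three substituted phenyl groups to compare, and 3-bromophenyl in place of 3,4-dichlorophenyl gives a 1.2-fold lower number from compound 2 to compound 3 (0.10 log units; within the scatter). The new comparison of the two bromophenyl groups, 3-bromophenyl in place of 4-bromophenyl, gives a 1.9-fold lower number from compound 1 to compound 3 (0.28 log units; within the scatter), so neither a change in where the bromine stands nor a change from two chlorines to one bromine carries the number beyond the scatter. No measurement at hand offers an explanation for these small steps.

The compounds shown leave open whether an unsubstituted phenyl, or a phenyl bearing an amine or a carboxylic acid, at this place would produce a step beyond the scatter. They also leave open whether the same small steps would appear in cells other than those of this assay.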